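The source may report more compounds than this note shows. Statements on the series, on what has been measured and on what is new or still open speak of the compounds shown alone.

Measured compounds:
- compound 1, `O=[N+]([O-])c1cc(CNCCCNC2CCCCC2)ccc1CNCCCNC1CCCCC1`, in an assay on CHO cells for displacement of a labelled ligand from C-X-C chemokine receptor type 4 (Homo sapiens), with a stated time of 40 min (on this read-out lower numbers stand for stronger inhibition and higher numbers for weaker inhibition), gives 354 nM
- compound 2, `Nc1cc(CNCCCNC2CCCCC2)ccc1CNCCCNC1CCCCC1`, in this assay gives 68.9 nM
- compound 3, `O=[N+]([O-])c1cc(CNCCCNC2CCCCC2)cc(CNCCCNC2CCCCC2)c1`, in this assay gives 147 nM

Compound 1 and compound 2 share one core and differ in a single spot: amino in place of nitro on an aromatic carbon. That change produced a 5.1-fold lower number from compound 1 to compound 2 (0.71 log units; beyond the scatter).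

Compound 3 carries the same atoms as compound 1 but joined differently, so the two cores are not the same; the difference between the two cores is not broken down here. On this second core the unmeasured compound 4, `Nc1cc(CNCCCNC2CCCCC2)cc(CNCCCNC2CCCCC2)c1`, is reached from compound 3 by amino in place of nitro on an aromatic carbon. Within the data shown here, this is the same kind of change as the one from compound 1 to compound 2, though the surroundings are not identical: in compound 1 the nitro sits ortho to a large group and meta to a large group, while in compound 3 it sits meta to two large groups.

Given that the earlier change made a 5.1-fold lower number from compound 1 to compound 2 (0.71 log units; beyond the scatter), a step of similar direction, if perhaps somewhat smaller, is expected here: compound 4 is expected to show a 3.7-fold lower number from compound 3 to compound 4 (0.57 log units; beyond the scatter). In this assay compound 4 is therefore estimated at 40 nM, likely between 15 nM and 100 nM.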

Compound 4, half-maximal inhibitory concentration: 81.2 nM
Compound 4: middle estimate off by 2.0-fold (0.31 log units), on the low side; measured number inside the range.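

In this assay, amino in place of nitro does not give the same result on the two cores: the same change on two cores in this assay, a 5.1-fold lower number (0.71 log units; beyond the scatter) from compound 1 to compound 2 and a 1.8-fold lower number (0.26 log units; within the scatter) from compound 3 to compound 4, 2.8-fold (0.45 log units) apart, beyond the scatter of two such steps. On the core of compound 3 the change gives a 1.8-fold lower number from compound 3 to compound 4 (0.26 log units; within the scatter), so these two compounds cannot be told apart here, and the clear step seen on the core of compound 1 cannot be assumed to carry over to another core. What the data do not show is why the two steps differ, and two pairs of compounds give no general rule for other cores in this series.

The compounds shown leave open whether another group at the same spot, such as a hydroxyl or a methyl, would also give different results on the two cores. They also leave open whether a longer chain in the two side arms would change the numbers on both cores alike.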